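The compounds below may be only part of what the source reports. "The series", "measured", "known", "first", "only" and "open" are said of these compounds alone.

Working notes on the series. Two compounds share the core of compound 1 `CC(C)=CCn1c(CN2CCN(C(=O)C3CC3)CC2)nc2ccccc21` and have been measured in an assay on isolated protein for inhibition of Retinaldehyde dehydrogenase 3 (Homo sapiens), read by spectrophotometry (a lower number here means a stronger inhibitor, a higher number a weaker inhibitor), where compound 1 gives 1270 nM. Compound 2 `CCC(=O)N1CCN(Cc2nc3ccccc3n2Cc2cccc(C)c2)CC1` differs from compound 1 at two places. In this assay compound 2 gives 1680 nM. Of the two numbers, compound 1 has the lower, but the gap to compound 2 is within the scatter of repeated measurements, so no order between the two can be claimed.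

Compound 3 `O=C(C1CC1)N1CCN(Cc2nc3ccccc3n2Cc2cccc(Cl)c2)CC1` has not yet been measured in this assay. It differs from compound 1 in one place: 3-chlorophenyl in place of 2-methylprop-1-en-1-yl on a saturated chain carbon bound to an aromatic nitrogen. Within the data shown here, no step between measured compounds isolates this change. What the two measured compounds show is that a benzyl-type substituent on the aromatic nitrogen, as in compound 2, sits within the scatter of the 2-methylprop-1-en-1-yl-bearing compound 1, though compound 2 also carries a different acyl group on the piperazine.

On that basis the step from compound 1 to compound 3 is expected to be small, no larger than the scatter, in either direction: a 1.1-fold lower number from compound 1 to compound 3 (0.02 log units; within the scatter). For compound 3 in this assay the estimate is 1200 nM, with a range from 450 nM to 3200 nM.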

Compound 3, half-maximal inhibitory concentration: 1010 nM
The estimate for compound 3 lay 1.2-fold (0.07 log units) above the measured number, within the range that was stated.
By their numbers in this assay, from the lowest: compounds 3, 1 and 2 (each within the scatter of the next).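

The step isolates one change with the rest of compound 1 held fixed: in this assay, 3-chlorophenyl in place of 2-methylprop-1-en-1-yl on a saturated chain carbon bound to an aromatic nitrogen gives a 1.3-fold lower number from compound 1 to compound 3 (0.10 log units; within the scatter). The earlier pair could not show this, since compound 2 also carries a different acyl group. At this position, then, a group with 4 heavy atoms, no ring and one double bond and a group with 7 heavy atoms and a six-membered aromatic ring give numbers within the scatter of each other, and no supporting measurement accounts for this result.

The compounds shown leave open whether the chlorine itself contributes anything, as they contain no pair that compares 3-chlorobenzyl with unsubstituted benzyl while keeping the acyl group the same. They also leave open whether the number would move beyond the scatter with a carboxylic acid or an amine on the aromatic ring in place of the chlorine, or with a longer chain in place of 3-methylbut-2-en-1-yl.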